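Extending the Chain of Compound 2

A few compounds are considered here, and "the series" means these few. Any claim that something is new, unique, unknown or untested is made for them only; others in the source may bear on it.

Measured in a functional assay on SW480 cells (Homo sapiens) for antiproliferative activity, read by MTT assay, with a stated time of 48 h; on this read-out lower numbers stand for stronger inhibition and higher numbers for weaker inhibition:
Compound 1 `CCCCCCCC(CCO)n1cnc2c(Cl)nc(Cl)nc21` gives 13600 nM
Compound 2 `CCCCCCCC(CCO)n1cnc2c(N)nc(Cl)nc21` gives > 50000 nM

Compound 2 is reported only as a limit, at > 50000 nM.

Compound 3 `CCCCCCCCCCC(CCO)n1cnc2c(N)nc(Cl)nc21` keeps the core of compound 2 and changes only the chain: propyl in place of hydrogen on a saturated chain carbon, eight bonds along the chain from an aromatic nitrogen.

Among the compounds with values here, the one measured step is an at least 3.6-fold higher number from compound 1 to compound 2 (0.56 log units; beyond the scatter), for amino in place of chloro on an aromatic carbon. Within the data shown here, that step leaves the chain untouched, so it offers only an indirect guide, and no measured step concerns the chain itself.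

A modest move toward lower numbers is expected in this assay, although another limit remains quite possible. The expected change is an at least 1.4-fold lower number from compound 2 to compound 3 (0.15 log units; that floor lies within the scatter). Compound 3 is estimated at 35000 nM, with an expected range of 12000 nM to 70000 nM.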

Compound 3, half-maximal inhibitory concentration: 13100 nM
Compound 3: middle estimate off by 2.7-fold (0.43 log units), on the high side; measured number inside the range.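

In this assay, the chain proves to be a working position: with the amino group and the rest of the core kept, propyl in place of hydrogen on a saturated chain carbon gives an at least 3.8-fold lower number from compound 2 to compound 3 (0.58 log units; beyond the scatter). The earlier step changed only a group on an aromatic carbon and moved toward higher numbers, whereas this change in the chain alone moves the other way and yields a measured number rather than a limit. The step can be read only as a floor, because compound 2 is reported as a limit: the limit of > 50000 nM in this assay, at which 1 of the 3 values shown sits.

As far as these compounds go, whether a still longer chain would lower the number further, or a chain ending in an amine or a carboxylic acid would do the same, remains open. Also open, from the compounds shown here alone, is whether the same extension would act alike with chloro in place of amino, as in compound 1.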